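A Pyrazolylmethyl Ether Gives Way to an Isopropyl Ether

A few compounds are considered here, and "the series" means these few. Any claim that something is new, unique, unknown or untested is made for them only; others in the source may bear on it.

Compound 1 `Cc1nn(-c2ncnc3nc[nH]c23)c2c1C(OCc1ccccc1F)CC(=O)N2` gives 4 nM in a functional assay on HEK293 cells for agonist activity at G-protein coupled receptor 39 (Homo sapiens), read by scintillation proximity assay and inositol phosphate accumulation, with a stated time of 75 min, in the presence of a further agent that is not named here; on this read-out higher numbers stand for an effect only at larger amounts of compound and lower numbers for an effect already at smaller amounts.
Compound 2 `Cc1nn(-c2ncnc3nc[nH]c23)c2c1C(OCCn1cccn1)CC(=O)N2` gives 16 nM in this assay.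

Compound 2 holds the higher of the two numbers, set apart from compound 1 by a 4.0-fold higher number from compound 1 to compound 2 (0.60 log units; beyond the scatter). Compound 3 `Cc1nn(-c2ncnc3nc[nH]c23)c2c1C(OCC(C)C)CC(=O)N2` differs from compound 2 by isopropyl in place of (1H-pyrazol-1-yl)methyl on a saturated chain carbon bound to an oxygen on a saturated carbon. Among the measured compounds shown here, the single measured step, a 4.0-fold higher number from compound 1 to compound 2 (0.60 log units; beyond the scatter), concerns the same place but exchanges one ring-bearing group for another, so it bears on this change only loosely. A further modest rise in the number is expected, a 2.5-fold higher number from compound 2 to compound 3 (0.40 log units; beyond the scatter). Compound 3 is therefore estimated at 40 nM, within 10 nM to 160 nM.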

Compound 3, half-maximal effective concentration: 4 nM
The estimate for compound 3 lay 10-fold (1.00 log units) above the measured number, outside the stated range (below it).
By their numbers in this assay, from the lowest: compounds 1 and 3 (each within the scatter of the next); then compound 2.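

In this assay, isopropyl in place of (1H-pyrazol-1-yl)methyl gives a 4.0-fold lower number from compound 2 to compound 3 (0.60 log units; beyond the scatter), so the pyrazole ring is not needed for a low number at this place. Isopropyl in place of 2-fluorophenyl gives no change at the digits printed from compound 1 to compound 3 (within the scatter), which shows that a chain with no ring can match an aromatic ring here, while the ring-bearing compound 2 stands apart from both. Nothing available explains this difference.

Open, going by these compounds, is whether a methyl group, a longer alkyl chain, or a chain ending in an amine or a carboxylic acid would hold the number at this place.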